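A few compounds are considered here, and "the series" means these few. Any claim that something is new, unique, unknown or untested is made for them only; others in the source may bear on it.

Two ureas open the series. Compound 1 `C[C@@H](NC(=O)Nc1ccc(F)cc1)c1ccccc1` and compound 2 `C[C@H](NC(=O)Nc1ccc(F)cc1)c1ccccc1` carry the same atoms and bonds and differ only in how the saturated chain carbon is drawn. In an ADME assay on the whole organism with Oryza sativa as the target, tested at 10 uM (a higher number here means a weaker effect of the compound at the concentration tested, a lower number a stronger effect), compound 1 gives 92%, and in this assay compound 2 gives 85%. The step of a number 7 percentage points lower from compound 1 to compound 2 (within the scatter) is what that inversion amounts to, and the fact that compounds 1 and 2 differ only in the configuration as drawn is all that separates the two numbers, which sit within the scatter of each other. Compound 2 thus stands beside compound 1 rather than apart from it.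

Compound 3 `C[C@H](NC(=O)Nc1ccc(F)cc1F)c1ccccc1` is the next compound, not yet measured in this assay. Its change from compound 2 is fluoro in place of hydrogen on an aromatic carbon. For the measured compounds named here, no measured step bears on such a change: the only step in hand, a number 7 percentage points lower from compound 1 to compound 2 (within the scatter), concerns configuration alone. On that basis compound 3 is expected to stay close to compound 2, a step of no change at the digits printed from compound 2 to compound 3 (within the scatter) of no size beyond the scatter. Compound 3 is estimated at 85%, with a range from 65% to 97%.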

Compound 3, a percentage reported as activity, at one concentration (the size of the read-out at that concentration, not a potency): 99%
Compound 3: the middle estimate sits 14 percentage points below what was measured; the measured number lies above the stated range.
By their numbers in this assay, from the lowest: compounds 2, 1 and 3 (each within the scatter of the next, the first and the last beyond it).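

Fluoro in place of hydrogen on an aromatic carbon, ortho to a large group and meta to a fluoro group, gives the first step in the series that lies beyond the scatter: a number 14 percentage points higher from compound 2 to compound 3 (beyond the scatter). In this assay a higher number means a weaker effect, so this aromatic position responds to the change, and compound 3 reads as the weaker of the pair, whereas the inversion between compounds 1 and 2 stayed within the scatter. Nothing at hand accounts for this step.

Going by these compounds, what a chloro, methyl or methoxy group would give on the same aromatic carbon remains open, so the step cannot yet be tied to fluoro in particular. Also open, on these data alone, is whether the same fluoro change would give a similar step on the configuration drawn in compound 1.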